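Swapping the Amide Substituent on a Vitamin D Receptor Agonist

A few compounds are considered here, and "the series" means these few. Any claim that something is new, unique, unknown or untested is made for them only; others in the source may bear on it.

Going by the values given here, compound 2 `CCOc1ccc(NC(=O)c2ccc(C(CC)(CC)c3ccc(OCCC(O)(CC)CC)c(C)c3)n2CC)cc1` is the only compound here with a numerical value in an assay on cells for agonist activity at vitamin D3 receptor (Homo sapiens), with a stated time of 96 h (on this read-out higher numbers stand for an effect only at larger amounts of compound and lower numbers for an effect already at smaller amounts), where compound 2 gives 1630 nM. Compound 1 `C=CCN(C)C(=O)c1ccc(C(CC)(CC)c2ccc(OCCC(O)(CC)CC)c(C)c2)n1CC` reaches only the limit of this assay, > 10000 nM. Among the compounds with values here, the single measured step, an at least 6.1-fold lower number from compound 1 to compound 2 (0.78 log units; beyond the scatter), also alters the group on the carbonyl carbon and rests on (the limit of > 10000 nM in this assay, at which 1 of the 2 values shown sits). Compound 3 `CCn1c(C(=O)NC(C)C(=O)O)ccc1C(CC)(CC)c1ccc(OCCC(O)(CC)CC)c(C)c1` differs from compound 2 in one place: 1-carboxyethyl in place of 4-ethoxyphenyl on an amide-type nitrogen. Within the data shown here, no measured step covers this change, so a step beyond the scatter in either direction remains possible. For compound 3 a modest rise in this assay is expected, a 2.1-fold higher number from compound 2 to compound 3 (0.33 log units; beyond the scatter). Compound 3 is therefore estimated at 3500 nM, within 800 nM to 15000 nM.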

Compound 3, half-maximal effective concentration: 66 nM
The estimate for compound 3 lay 53-fold (1.72 log units) above the measured number, and the stated range ends above it.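

In this assay, 1-carboxyethyl on the amide-type nitrogen gives a 25-fold lower number from compound 2 to compound 3 (1.39 log units; beyond the scatter), so a six-membered aromatic ring is not required at this position, and a group with no ring can give the lower number. Compound 1 stands at a limit of the assay, > 10000 nM. The wider comparison, an at least 150-fold lower number from compound 1 to compound 3 (2.18 log units; beyond the scatter), is read against that limit: the limit of > 10000 nM in this assay, at which 1 of the 3 values shown sits.

As far as these compounds go, whether the carboxylic acid itself matters remains open. Its methyl ester or a primary amide on the same chain would test this, and a carboxymethyl or 2-carboxypropyl group would probe the chain around the acid.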